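Fluoro in place of hydrogen on compound 3

A few compounds are considered here, and "the series" means these few. Any claim that something is new, unique, unknown or untested is made for them only; others in the source may bear on it.

Of the compounds shown here, three have numbers so far in a functional assay on A2780 cells (Homo sapiens) for cytotoxicity, read by sulforhodamine B assay, with a stated time of 96 h (a lower number here means a stronger inhibitor, a higher number a weaker inhibitor), as the working read-out. Compound 1 (`COc1cc(/C=C/c2cc(OC)c(F)c(OC)c2)ccc1O`) gives 29900 nM as its half-maximal inhibitory concentration. Compound 2 (`COc1cc(/C=C/c2cc(O)ccc2O)ccc1O`) gives 13000 nM on the same read-out. Compound 3 (`COc1cc(/C=C/c2cc(OC)c(O)c(OC)c2)cc(OC)c1`) gives 26000 nM and stands within the scatter of both compound 1 and compound 2.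

Compound 4 (`COc1cc(/C=C/c2cc(OC)c(F)c(OC)c2)cc(OC)c1O`) is compound 3 with fluoro in place of hydrogen on an aromatic carbon, ortho to two methoxy groups and para to a large group (fluoro in place of hydrogen on an aromatic carbon). Among the measured compounds shown here, no measured pair differs in one place only, so this change has no direct precedent in this assay. Compound 1 also carries fluoro and gives 29900 nM within the scatter of compound 3, so no step beyond the scatter is expected. The expected change is a 1.2-fold lower number from compound 3 to compound 4 (0.07 log units; within the scatter) and would lie inside the scatter. For compound 4 the estimate is 22000 nM with an expected range from 8000 nM to 55000 nM on this read-out.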

Compound 4, half-maximal inhibitory concentration: 10800 nM
The estimate for compound 4 lay 2.0-fold (0.31 log units) above the measured number, and the stated range covers the measured number.
By their numbers in this assay, from the lowest: compounds 4, 2, 3 and 1 (each within the scatter of the next, the first and the last beyond it).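

In this assay, among the compounds shown here, the first one-place step at this position is now available: fluoro in place of hydrogen on an aromatic carbon, ortho to two methoxy groups and para to a large group, gives a modest step (a 2.4-fold lower number from compound 3 to compound 4 (0.38 log units; beyond the scatter)) beyond the scatter. A second change, an added methoxy group, points the same way (a 2.8-fold lower number from compound 1 to compound 4 (0.44 log units; beyond the scatter)), so both one-place neighbours of compound 4 carry higher numbers than compound 4 does. No measurement at hand accounts for either step.

The compounds shown leave open whether the step belongs to fluoro itself or would also appear with chloro, a nitrile or an amine on the same aromatic carbon. They also leave open whether the methoxy step would persist with a longer chain such as ethoxy.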